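The compounds below may be only part of what the source reports. "The series", "measured", "known", "first", "only" and "open" are said of these compounds alone.

Series notes. Going by the values given here, compound 1 `Oc1cccc(-c2cc(-c3ccccc3)cc(-c3ccco3)n2)c1` is the first measured member; in a functional assay on MDA-MB-231 cells (Homo sapiens) for cytotoxicity, read by ELISA, with a stated time of 2 days (a higher number here means a weaker inhibitor, a lower number a stronger inhibitor), compound 1 gives 13700 nM. Compound 2 `Oc1ccc(-c2cc(-c3ccccc3)cc(-c3ccco3)n2)cc1` differs from compound 1 only by 4-hydroxyphenyl in place of 3-hydroxyphenyl on an aromatic carbon, and in this assay compound 2 gives 1400 nM, which is a 9.8-fold lower number from compound 1 to compound 2 (0.99 log units; beyond the scatter). Compound 3 `Oc1cccc(-c2cc(-c3ccccc3)nc(-c3ccco3)c2)c1` carries the same three substituents on a core joined differently; how the core of compound 3 differs from the core of compound 1 is not broken down here. In this assay compound 3 gives 20800 nM, the highest of the three numbers, within the scatter of compound 1 and beyond the scatter of compound 2.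

Compound 4 `Oc1ccc(-c2cc(-c3ccccc3)nc(-c3ccco3)c2)cc1` stands to compound 3 as compound 2 stands to compound 1, by 4-hydroxyphenyl in place of 3-hydroxyphenyl on an aromatic carbon. It is the same kind of change as that from compound 1 to compound 2, not the same change: in compound 1 the hydroxyphenyl sits next to the ring nitrogen, in compound 3 it sits opposite the ring nitrogen, in both cases meta to the furan-2-yl group and meta to the phenyl group. Among the compounds with values here, only one instance of the change has been measured, so its transfer to the other place is untested. Within the data shown here, compound 4 is expected to give 4000 nM in this assay, a step of a 5.2-fold lower number from compound 3 to compound 4 (0.72 log units; beyond the scatter) that is estimated because the one measured step, a 9.8-fold lower number from compound 1 to compound 2 (0.99 log units; beyond the scatter), was beyond the scatter; the range 1500 nM to 12000 nM is estimated to allow for the different place.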

Compound 4, half-maximal inhibitory concentration: 1000 nM
Estimate against measurement, compound 4: 4.0-fold (0.60 log units) above; measured number below the stated range.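

In this assay, 4-hydroxyphenyl in place of 3-hydroxyphenyl gives a 21-fold lower number from compound 3 to compound 4 (1.32 log units; beyond the scatter), and set beside the earlier step, the two instances do not differ: the same change on two cores in this assay, a 9.8-fold lower number (0.99 log units; beyond the scatter) from compound 1 to compound 2 and a 21-fold lower number (1.32 log units; beyond the scatter) from compound 3 to compound 4, 2.1-fold (0.33 log units) apart, within the scatter of two such steps

Within these four compounds, the change therefore carries from the core of compound 1 to the core of compound 3, with the same direction and a size that cannot be told apart, and in both pairs the 4-hydroxyphenyl compound has the lower number. Going by these compounds alone, this rests on only two cores, one pair of hydroxyphenyl groups and one cell assay, so it does not show that the step would hold on any other core, with other groups in place of furan-2-yl or phenyl, or in other cells, and it gives no reason for the step.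

The compounds shown leave open whether the hydroxyl itself is needed for the lower number, as all four carry it and none has a methoxy group, an amine or a carboxylic acid in its place. They also leave open how much furan-2-yl and phenyl contribute, since both stay unchanged throughout and no compound shown has, for example, a longer alkyl chain at either place.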